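The compounds below may be only part of what the source reports. "The series", "measured", "known", "first", "only" and "open" are said of these compounds alone.

Measured so far: compound 1 `O=C(CCc1ccc(-c2ccccc2Cl)cc1)N1CCCC1` and compound 2 `O=C(CCc1ccc(-c2cccs2)cc1)N1CCCC1`.

In an assay on HEK293 cells for inhibition of N-acylethanolamine-hydrolyzing acid amidase (Rattus norvegicus), read by LC-MS, with a stated time of 30 min (on this read-out lower numbers stand for stronger inhibition and higher numbers for weaker inhibition), compound 1 reaches only the limit of the assay, > 100000 nM. In this assay compound 2 likewise reaches only the limit, > 100000 nM. Among the compounds with values here, compound 2 therefore stands only at a limit, as does the single other value shown (the limit of > 100000 nM in this assay, at which 2 of the 2 values shown sit). The step from compound 1 to compound 2 is unreadable a step that the two limits leave unreadable from compound 1 to compound 2.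

Compound 3 `O=C(CCc1ccc(-c2ccsc2)cc1)N1CCCC1` differs from compound 2 by thiophen-3-yl in place of thiophen-2-yl on an aromatic carbon. Within the data shown here, only that unreadable step bears on this change, so no direction or size can be read from it. Compound 3 is expected to give about 150000 nM, between 30000 nM and 600000 nM, in this assay. The implied step from compound 2 to compound 3 is expected to be a step that the limit leaves unreadable from compound 2 to compound 3, most likely again a limit.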

Compound 3, half-maximal inhibitory concentration: 2500 nM
Compound 3: the middle estimate sits 60-fold (1.78 log units) above what was measured; measured number below the stated range.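

In this assay, thiophen-3-yl in place of thiophen-2-yl on the aromatic carbon gives an at least 40-fold lower number from compound 2 to compound 3 (1.60 log units; beyond the scatter), so with the same atoms joined differently, the point of attachment of the ring separates a readable value from a limit. Thiophen-3-yl in place of 2-chlorophenyl gives an at least 40-fold lower number from compound 1 to compound 3 (1.60 log units; beyond the scatter). Before this result, the position had shown no readable value: the limit of > 100000 nM in this assay, at which 2 of the 3 values shown sit.

The compounds shown leave open whether other groups at this position, such as furan-3-yl or an aminomethyl group, would lower the number further. They also leave open whether the change would hold with a longer chain in the core.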